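The compounds below may be only part of what the source reports. "The series", "measured", "known", "first", "only" and "open" are said of these compounds alone.

Two compounds in this series share a core that carries a sulfonamide on one end of a three-carbon chain and a benzylic amine on the other, differing only in the aryl group that sits on a saturated chain carbon bound to an amine nitrogen. Compound 1 `O=S(=O)(NCCCNCc1ccc(Cl)c(C(F)(F)F)c1)c1cc(C(F)(F)F)cc(C(F)(F)F)c1` carries a 4-chloro-3-(trifluoromethyl)phenyl there, and in a functional assay on ASPC1 cells (Homo sapiens) for inhibition, read by MTT assay, with a stated time of 72 h (on this read-out higher numbers stand for weaker inhibition of growth and lower numbers for stronger inhibition of growth), compound 1 gives 9600 nM. Compound 2 `COc1ccc(CNCCCNS(=O)(=O)c2cc(C(F)(F)F)cc(C(F)(F)F)c2)cc1` carries a 4-methoxyphenyl instead, and in this assay compound 2 gives 2800 nM. The step of a 3.4-fold lower number from compound 1 to compound 2 (0.54 log units; beyond the scatter) puts compound 2 at the lowest number of the two shown.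

Compound 3 `COc1ccccc1CNCCCNS(=O)(=O)c1cc(C(F)(F)F)cc(C(F)(F)F)c1` is the next member. Its difference from compound 2 is 2-methoxyphenyl in place of 4-methoxyphenyl on a saturated chain carbon bound to an amine nitrogen. Within the data shown here, no measured step moves the methoxy group around the ring while keeping it; the only measured step swaps one aryl group for a different one, so it gives no direct guidance on how large a step to expect here. Without such a comparison, the step of a 1.1-fold higher number from compound 2 to compound 3 (0.06 log units; within the scatter) is expected to stay within the usual scatter, with no clear direction. Compound 3 is therefore estimated to give 3200 nM in this assay, within a range from 1200 nM to 9000 nM.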

Compound 3, concentration for 50% growth inhibition: 4600 nM
Beside the measured number, compound 3's estimate is 1.4-fold (0.16 log units) below it; the measured number falls inside the stated range.
By their numbers in this assay, from the lowest: compounds 2 and 3 (each within the scatter of the next); then compound 1.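

Within this series, the place of the methoxy group on the ring has little visible effect: swapping 4-methoxyphenyl for 2-methoxyphenyl gives a 1.6-fold higher number from compound 2 to compound 3 (0.22 log units; within the scatter), so this assay does not separate these two compounds. The comparison with the chlorinated aryl group now rests on two methoxy compounds rather than one, as 2-methoxyphenyl in place of 4-chloro-3-(trifluoromethyl)phenyl gives a 2.1-fold lower number from compound 1 to compound 3 (0.32 log units; beyond the scatter), a modest step in the same direction as the one seen with 4-methoxyphenyl. No measurement is available that would explain either step.

The compounds shown cannot tell whether the gain over compound 1 comes from having a methoxy group or from losing the chlorine and trifluoromethyl groups, since those changes occur together in each step. A plain phenyl, a 3-methoxyphenyl or a 4-chlorophenyl group at this place on the saturated chain carbon bound to an amine nitrogen would help separate these possibilities, and a longer chain between the two nitrogens remains an open question as well.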